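A few compounds are considered here, and "the series" means these few. Any claim that something is new, unique, unknown or untested is made for them only; others in the source may bear on it.

Series notes. The shared core of compound 1, `CC1(C)N(O)C(c2ccc(O)cc2)=[N+]([O-])C1(C)C`, carries a free phenol; in a functional assay on PC-12 cells (Rattus norvegicus) for inhibition, read by MTT assay (a lower number here means that less compound is needed, a higher number that more compound is needed for the effect), compound 1 gives 56900 nM. Compound 2, `CC1(C)N(O)C(c2ccc(OCC(=O)N[C@@H](CCCCN)C(=O)O)cc2)=[N+]([O-])C1(C)C`, extends the phenol oxygen through an acetamide to a lysine unit; in this assay compound 2 gives 99100 nM. Compound 3, `CC1(C)N(O)C(c2ccc(OCC(=O)NCCCC[C@H](N)C(=O)O)cc2)=[N+]([O-])C1(C)C`, links the same lysine through its side-chain nitrogen instead; in this assay compound 3 gives 98800 nM. The step of a 1.0-fold lower number from compound 2 to compound 3 (0.00 log units; within the scatter) lies within the scatter. The gap between compound 3 and compound 1 also lies within the scatter, so compound 3 stands among three numbers that cannot be separated from one another.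

Compound 4, `CC(C)(C)OC(=O)N[C@@H](CCCCNC(=O)COc1ccc(C2=[N+]([O-])C(C)(C)C(C)(C)N2O)cc1)C(=O)O`, differs from compound 3 by tert-butoxycarbonyl in place of hydrogen on an amine nitrogen. Among the compounds with values here, no measured step touches this amine nitrogen, and the only step recorded, a 1.0-fold lower number from compound 2 to compound 3 (0.00 log units; within the scatter), shows that rearranging the lysine attachment left the number unchanged. The series gives no basis for a shift beyond the scatter. The step from compound 3 to compound 4 is therefore expected to be a 1.0-fold higher number from compound 3 to compound 4 (0.00 log units; within the scatter) in this assay. Compound 4 is estimated at 99000 nM, in the range 40000 nM to 250000 nM.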

Compound 4, half-maximal effective concentration: 97700 nM
The estimate for compound 4 lay 1.0-fold (0.01 log units) above the measured number; the measured number falls inside the stated range.
By their numbers in this assay, from the lowest: compounds 1, 4, 3 and 2 (each within the scatter of the next).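

In this assay, tert-butoxycarbonyl in place of hydrogen on the amine nitrogen gives a 1.0-fold lower number from compound 3 to compound 4 (0.00 log units; within the scatter). Within the data shown here, this is the first step at this nitrogen itself, since the earlier step concerned only how the lysine unit is attached. It shows that the free amine of compound 3 can be replaced by a carbamate of 7 heavy atoms with no change beyond the scatter in this assay, so the amine hydrogen is not needed to hold the number at this level. Nothing measured here accounts for this result.

Still open, as far as these compounds go, is whether tert-butoxycarbonyl on the free amine of compound 2 would give the same outcome. A methyl ester in place of the carboxylic acid, or a longer chain on this nitrogen, might also move the number beyond the scatter.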